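The compounds below may be only part of what the source reports. "The series", "measured", "known", "first", "only" and "open" are said of these compounds alone.

Measured in an ADME assay on HaCaT cells (Homo sapiens) for inhibition (on this read-out lower numbers stand for stronger inhibition and higher numbers for weaker inhibition), so far:
Compound 1 `COc1cc(-c2cc(C(=O)O)c3ccccc3n2)ccc1OCC(=O)Nc1cccc(Cl)c1`: 192000 nM
Compound 2 `COc1cc(-c2cc(C(=O)O)c3ccccc3n2)ccc1OCC(=O)Nc1ccc(C(F)(F)F)cc1`: 150000 nM
Compound 3 `COc1cc(-c2cc(C(=O)O)c3ccccc3n2)ccc1OCC(=O)NCc1ccccc1`: only a limit of the assay, > 300000 nM

As far as these compounds go, compound 3 thus sits at the ceiling of this assay, namely (the limit of > 300000 nM in this assay, at which 1 of the 3 values shown sits), so its true value is unknown. The measured steps are all small: a 1.3-fold lower number from compound 1 to compound 2 (0.11 log units; within the scatter), an at least 1.5-fold higher number from compound 1 to compound 3 (0.19 log units; that floor lies within the scatter) and an at least 2.0-fold higher number from compound 2 to compound 3 (0.30 log units; that floor lies within the scatter). Compound 4 `CCCCCCNC(=O)COc1ccc(-c2cc(C(=O)O)c3ccccc3n2)cc1OC` differs from compound 3 in one place: pentyl in place of phenyl on a saturated chain carbon bound to an amide-type nitrogen. Among the compounds with values here, no measured step swaps an aromatic group for a chain, so the three steps offer little guidance on direction, and all lie within the scatter. Starting from a limit, compound 4 is expected to stay at or past that ceiling, with an expected step that the limit leaves unreadable from compound 3 to compound 4. The estimate for compound 4 is 400000 nM, in a range from 150000 nM to 1200000 nM.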

Compound 4, half-maximal inhibitory concentration: > 300000 nM
Compound 4: no number, only a limit; the forecaster's own chance of this, stated with the estimate: 70%; the middle value lies beyond the limit too.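

In this assay compound 4, with its hexyl chain on the amide-type nitrogen, gives only a limit, so an open chain at this place reaches the same ceiling as the benzyl group of compound 3. Set against the aromatic groups, the result is an at least 2.0-fold higher number from compound 2 to compound 4 (0.30 log units; that floor lies within the scatter) and also an at least 1.5-fold higher number from compound 1 to compound 4 (0.19 log units; that floor lies within the scatter) and neither floor shows a real gap. The step from compound 3 to compound 4 cannot be read, because both values are limits: the limit of > 300000 nM in this assay, at which 2 of the 4 values shown sit.

As far as these compounds go, how far compound 3 and compound 4 lie past that limit stays open. So does how a longer chain, or a hexyl chain ending in an amine, would read here.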